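The source may report more compounds than this note shows. Statements on the series, on what has been measured and on what is new or still open speak of the compounds shown alone.

Compound 1 `Cc1c(OCCCCOc2ccc(C(=O)O)cc2Cl)ccc(C(=O)CC2CCCC2)c1O` is the starting point. In an assay on HEK293 cells for positive allosteric modulation of metabotropic glutamate receptor 3 (Rattus norvegicus), read by thallium flux, with a stated time of 2.5 min (a higher number here means that more compound is needed for the effect, a lower number that less compound is needed), compound 1 gives > 10000 nM, which is a limit of the assay rather than a number, so compound 1 stands at the limit of > 10000 nM in this assay, at which 1 of the 3 values shown sits. Compound 2 `COc1ccc(C(=O)O)cc1OCCCCOc1ccc(C(=O)CC(C)C)c(O)c1C` shares the same core, and in this assay compound 2 gives 737 nM. Compound 3 `Cc1c(OCCCCOc2ccc(C(=O)O)cc2)ccc(C(=O)CC(C)C)c1C` has "not determined" (no result reported) in this assay, so no number is known for it. Compound 4 `Cc1c(OCCCCOc2ccc(C(=O)O)c(Cl)c2)ccc(C(=O)CC2CCCC2)c1O` differs from compound 1 in one place: 4-carboxy-3-chlorophenyl in place of 4-carboxy-2-chlorophenyl on an oxygen on a saturated carbon. Within the data shown here, no pair of measured compounds here differs by a single change, so the size of this kind of change has not been seen directly; the expected step from compound 1 to compound 4 is an at least 2.0-fold lower number from compound 1 to compound 4 (0.30 log units; that floor lies within the scatter), a modest gain at best. For compound 4 the estimate is 5000 nM, with a range from 1500 nM to 20000 nM.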

Compound 4, half-maximal effective concentration: 2250 nM
Estimate against measurement, compound 4: 2.2-fold (0.35 log units) above; measured number inside the range.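

Among the compounds shown, this is the first single change that can be read in this assay: with the same atoms joined differently, 4-carboxy-3-chlorophenyl in place of 4-carboxy-2-chlorophenyl gives an at least 4.4-fold lower number from compound 1 to compound 4 (0.64 log units; beyond the scatter). So the arrangement of this ring alone can shift the read-out beyond the scatter. The true size of the step stays unknown, and only its floor can be read, because compound 1 stands at a limit: the limit of > 10000 nM in this assay, at which 1 of the 4 values shown sits.

The compounds shown leave open how a fluorine or a nitrile in place of this chlorine would read.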